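Replacing the Carboxy Group of Compound 3 by Propoxymethyl

The source may hold more compounds than are shown below. What is called first, only, known or untested is meant among the compounds shown, and "the series" means these compounds.

Compound 1, `Nc1ccc(-c2cc(=O)c3c(N)c(F)c(CO)c(F)c3o2)cc1F`, gives 24000 nM in a functional assay on HeLa cells (Homo sapiens) for cytotoxicity, read by neutral red uptake, with a stated time of 3 days; a higher number here means a weaker inhibitor, a lower number a stronger inhibitor.
Compound 2, `[N-]=[N+]=Nc1c(F)c(N)c2c(=O)cc(-c3ccc(N)c(F)c3)oc2c1F`, gives 1200 nM in this assay.
Compound 3, `Nc1ccc(-c2cc(=O)c3c(N)c(F)c(C(=O)O)c(F)c3o2)cc1F`, gives only a limit of > 100000 nM in this assay.

Compound 3 therefore stands at the limit of > 100000 nM in this assay, at which 1 of the 3 values shown sits, with no number of its own, while compound 1 and compound 2 both give numbers well below that limit. Compound 4, `CCCOCc1c(F)c(N)c2c(=O)cc(-c3ccc(N)c(F)c3)oc2c1F`, differs from compound 3 in one place: propoxymethyl in place of carboxy on an aromatic carbon. Going by the values given here, two measured steps bear on this change. an at least 4.1-fold higher number from compound 1 to compound 3 (0.61 log units; beyond the scatter), and an at least 83-fold higher number from compound 2 to compound 3 (1.92 log units; beyond the scatter). Both steps show that the carboxy group goes with the highest number, so replacing it with propoxymethyl, a group closer to the hydroxymethyl of compound 1, is expected to give a lower number in this assay. The step is expected to be an at least 6.6-fold lower number from compound 3 to compound 4 (0.82 log units; beyond the scatter). Compound 4 is estimated at 15000 nM, within a range of 4000 nM to 60000 nM.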

Compound 4, half-maximal inhibitory concentration: 78000 nM
Compound 4: middle estimate off by 5.2-fold (0.72 log units), on the low side; measured number above the stated range.
By their numbers in this assay, from the lowest: compound 2; then compound 1; then compound 4. At a limit, above all of these: compound 3.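

In this assay, propyl on the oxygen of the hydroxymethyl group weakens compound 1 only modestly (a 3.3-fold higher number from compound 1 to compound 4 (0.51 log units; beyond the scatter)), while the azido group keeps a large advantage over propoxymethyl at this position (a 65-fold higher number from compound 2 to compound 4 (1.81 log units; beyond the scatter)). The gain over carboxy is not established, since its floor lies within the scatter (an at least 1.2-fold lower number from compound 3 to compound 4 (0.10 log units; that floor lies within the scatter)). Compound 3 has no number of its own, only a limit: the limit of > 100000 nM in this assay, at which 1 of the 4 values shown sits.

As far as these compounds go, whether methoxymethyl, a longer chain or an amine at this position would come closer to the azido compound remains open.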